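This account rests on a few compounds, and the source may have more. Where it says the series, first, only, none or still open, it means among the compounds named here.

The three measured compounds share one core. Compound 1 `CCOC(=O)NC(=O)NC1=CS(=O)(=O)O[C@@]12[C@@H](CO[Si](C)(C)C(C)(C)C)O[C@@H](n1cc(C)c(=O)n(C)c1=O)[C@@H]2O[Si](C)(C)C(C)(C)C` carries an (ethoxycarbonyl)amino group on the carbonyl carbon; in a functional assay on HEL cells (Homo sapiens) (on this read-out higher numbers stand for lower toxicity in this test and lower numbers for higher toxicity in this test), compound 1 gives 14000 nM. Compound 2 `Cc1cn([C@@H]2O[C@H](CO[Si](C)(C)C(C)(C)C)[C@@]3(OS(=O)(=O)C=C3NC(N)=O)[C@H]2O[Si](C)(C)C(C)(C)C)c(=O)n(C)c1=O` has hydrogen in place of ethoxycarbonyl on an amide-type nitrogen, and in this assay compound 2 gives 11000 nM, a move of a 1.3-fold lower number from compound 1 to compound 2 (0.10 log units; within the scatter). Compound 3 `COC(=O)NC1=CS(=O)(=O)O[C@@]12[C@@H](CO[Si](C)(C)C(C)(C)C)O[C@@H](n1cc(C)c(=O)n(C)c1=O)[C@@H]2O[Si](C)(C)C(C)(C)C` carries methoxy on the carbonyl carbon. In this assay compound 3 reaches only a limit of the assay, > 200000 nM, so its position is fixed solely by the limit of > 200000 nM in this assay, at which 1 of the 3 values shown sits. The steps onto it are large, an at least 14-fold higher number from compound 1 to compound 3 (1.15 log units; beyond the scatter) and an at least 18-fold higher number from compound 2 to compound 3 (1.25 log units; beyond the scatter), both beyond the scatter.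

Compound 4 `Cc1cn([C@@H]2O[C@H](CO[Si](C)(C)C(C)(C)C)[C@@]3(OS(=O)(=O)C=C3NC(=O)NC(=O)c3ccccc3)[C@H]2O[Si](C)(C)C(C)(C)C)c(=O)n(C)c1=O` differs from compound 3 by benzamido in place of methoxy on a carbonyl carbon. Both measured steps that bear on this place ran from an amino-type group to methoxy and lifted the number past the limit; the change to compound 4 runs the other way, putting a group joined through an amide-type nitrogen back onto the carbonyl carbon, as in compound 1 and compound 2. The expected step in this assay is therefore downward, an at least 13-fold lower number from compound 3 to compound 4 (1.12 log units; beyond the scatter), toward the region of compound 1 and compound 2. Compound 4 is estimated at 15000 nM, within a range from 5000 nM to 60000 nM.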

Compound 4, half-maximal cytotoxic concentration: >= 200000 nM
Compound 4 gave a limit, no number (the forecaster's own chance of this, stated with the estimate: 25%); at least 13-fold (1.12 log units) between middle value and limit.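

In this assay compound 4 gives >= 200000 nM, a limit and not a number, and the step to it from compound 3, also a limit, cannot be read. Benzoyl in place of hydrogen on the amide-type nitrogen gives an at least 18-fold higher number from compound 2 to compound 4 (1.25 log units; beyond the scatter), and phenyl in place of ethoxy on the carbonyl carbon gives an at least 14-fold higher number from compound 1 to compound 4 (1.15 log units; beyond the scatter). Among the four compounds, then, the high end of the scale is no longer reached with methoxy alone, and a group joined through an amide-type nitrogen does not by itself keep the number in the region of compound 1 and compound 2, since benzamido in compound 4 goes against that reading.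

The compounds shown leave open whether the phenyl ring is what separates compound 4 from compound 1, a question that acetamido or cyclohexanecarboxamido on the same carbonyl carbon would address. They also leave open how far compound 3 and compound 4 lie past the limit, and where a simple amine such as methylamino or dimethylamino would fall at this place.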